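The compounds below may be only part of what the source reports. "The series", "measured", "known", "first", "only" and "open" are said of these compounds alone.

Measured so far in a functional assay on HepG2 cells (Homo sapiens) for cytotoxicity, read by MTT assay, with a stated time of 48 h; a higher number here means a weaker inhibitor, a lower number a stronger inhibitor:
- compound 1 `COc1cc(-c2nnc3n2NC(c2ccco2)C(C(=O)c2ccc(Cl)cc2)S3)cc(OC)c1OC`: 78600 nM
- compound 2 `COc1cc(-c2nnc3n2NC(c2cccs2)C(C(=O)c2ccc(F)cc2)S3)cc(OC)c1OC`: 54200 nM
- compound 3 `COc1cc(C(=O)C2Sc3nnc(-c4cc(OC)c(OC)c(OC)c4)n3NC2c2cccs2)cc(OC)c1OC`: a limit, > 100000 nM

Compound 1 and compound 2 lie within the usual scatter of each other in this assay. Compound 3 gives only a limit, as noted in the limit of > 100000 nM in this assay, at which 1 of the 3 values shown sits. Compound 4 `COc1ccc(C(=O)C2Sc3nnc(-c4cc(OC)c(OC)c(OC)c4)n3NC2c2ccco2)cc1` differs from compound 1 by methoxy in place of chloro on an aromatic carbon. Going by the values given here, no measured step makes that exact change; the only step on the carbonyl-bound ring is an at least 1.8-fold higher number from compound 2 to compound 3 (0.26 log units; that floor lies within the scatter), which also introduced methoxy groups and ended at the limit. Compound 4 is therefore expected to give 100000 nM, within 40000 nM to 250000 nM. That expectation amounts to a 1.3-fold higher number from compound 1 to compound 4 (0.10 log units; within the scatter), and a limit is a real possibility.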

Compound 4, half-maximal inhibitory concentration: > 100000 nM
Compound 4 ended at the assay's limit; the forecaster's own chance of this, stated with the estimate: 45%; the middle value lies on the limit itself.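

In this assay, the change from 4-chlorophenyl to 4-methoxyphenyl on the carbonyl gives an at least 1.2-fold higher number from compound 1 to compound 4 (0.10 log units; that floor lies within the scatter). Compound 4 gives a limit and not a number, so this step has only a floor, which does not separate methoxy from chloro. The earlier step on this ring brought in 3,4,5-trimethoxyphenyl, and a single methoxy in place of chloro now also ends at a limit: the limit of > 100000 nM in this assay, at which 2 of the 4 values shown sit.

On these data alone, how far compound 4 truly lies from compound 1 stays open. So does how an amine or a carboxylic acid at this place would read in this assay.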